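A few compounds are considered here, and "the series" means these few. Any claim that something is new, unique, unknown or untested is made for them only; others in the source may bear on it.

Measured compounds in a functional assay on L1210 cells (Mus musculus) for antiproliferative activity, with a stated time of 48 h; a lower number here means a stronger inhibitor, a higher number a weaker inhibitor:
compound 1 `C=C(Br)C(=O)Nc1ccc(C(=O)/C=C/c2cccc(OC)c2)cc1` gives 1100 nM;
compound 2 `C=C(Br)C(=O)Nc1ccc(C(=O)/C=C/c2ccccc2OC)cc1` gives 1700 nM;
compound 3 `C=C(Br)C(=O)Nc1ccc(C(=O)/C=C/c2ccc(OC)cc2OC)cc1` gives 520 nM.

Compound 1 and compound 2 share the same atoms joined differently, the difference being (3-methoxyphenyl in place of 2-methoxyphenyl on a double-bonded chain carbon bound to a double-bonded chain carbon); in this assay the step is a 1.5-fold higher number from compound 1 to compound 2 (0.19 log units; within the scatter). From compound 2 to compound 3 the change is methoxy in place of hydrogen on an aromatic carbon, and the step is a 3.3-fold lower number from compound 2 to compound 3 (0.51 log units; beyond the scatter).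

Compound 4 `C=C(Br)C(=O)Nc1ccc(C(=O)/C=C/c2cc(OC)cc(OC)c2)cc1` is not yet measured. It arises from compound 1 by methoxy in place of hydrogen on an aromatic carbon. Within the data shown here, this is the same kind of change as the one from compound 2 to compound 3, not the same: there the entering methoxy sits meta to a methoxy group and para to a large group, whereas in compound 4 it sits meta to a large group and meta to a methoxy group.

The step from compound 1 to compound 4 is expected to be a 1.8-fold lower number from compound 1 to compound 4 (0.26 log units; within the scatter), a smaller step than the earlier one, because a 3.3-fold lower number from compound 2 to compound 3 (0.51 log units; beyond the scatter) was seen at a differently placed position. Compound 4 is estimated at 600 nM, between 250 nM and 1400 nM.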

Compound 4, half-maximal inhibitory concentration: 2700 nM
Compound 4: the middle estimate sits 4.5-fold (0.65 log units) below what was measured; the whole stated range lies below it.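

In this assay the entering methoxy gave a 2.5-fold higher number from compound 1 to compound 4 (0.39 log units; beyond the scatter), a weakening where the same change had strengthened compound 2. The two steps run in opposite directions and do not agree, so this change cannot be carried from one core to the other in this series as a fixed increment: the same change on two cores in this assay, a 3.3-fold lower number (0.51 log units; beyond the scatter) from compound 2 to compound 3 and a 2.5-fold higher number (0.39 log units; beyond the scatter) from compound 1 to compound 4, 8.0-fold (0.90 log units) apart, beyond the scatter of two such steps. What this does not show is why they differ: the entering methoxy in compound 4 sits meta to a large group and meta to a methoxy group, and with one step on each core, the place of the group cannot be separated from the rest of the core.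

The compounds shown leave open whether a hydroxy group or an amine at that place on the aromatic ring would follow the methoxy step. They also leave open whether a longer chain, such as ethoxy, would do the same.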